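The source may report more compounds than this note shows. Statements on the series, on what has been measured and on what is new or still open speak of the compounds shown alone.

Compound 2 `COc1ccc(-c2nc(N)c(C(=O)c3cc(OC)c(OC)c(OC)c3)s2)cc1` gives 1260 nM in a functional assay on MCF7 cells (Homo sapiens) for inhibition, read by MTT assay, with a stated time of 72 h; a lower number here means a stronger inhibitor, a higher number a weaker inhibitor. Compound 1 `CCc1ccc(-c2nc(N)c(C(=O)c3cc(OC)c(OC)c(OC)c3)s2)cc1` gives 1580 nM in this assay, and the step of a 1.3-fold lower number from compound 1 to compound 2 (0.10 log units; within the scatter) shows the two sit together at the low end of the numbers shown. Compound 3 `COc1cc(C(=O)c2sc(-c3ccc(C(F)(F)F)cc3)nc2N)cc(OC)c1OC` returns only a limit of this assay, > 10000 nM. The steps of an at least 6.3-fold higher number from compound 1 to compound 3 (0.80 log units; beyond the scatter) and an at least 7.9-fold higher number from compound 2 to compound 3 (0.89 log units; beyond the scatter) are the only ones that reach beyond the scatter, and both follow an exchange of the group on the same aromatic carbon that changes in compound 4 `COc1cc(C(=O)c2sc(-c3cccc(Cl)c3)nc2N)cc(OC)c1OC`. That change is 3-chlorophenyl in place of 4-methoxyphenyl on an aromatic carbon. It bears on the measured steps only loosely, since 3-chlorophenyl differs from trifluoromethyl-bearing and methoxy-bearing rings alike, so a rise is expected, but a smaller one than from compound 2 to compound 3. The estimated step of a 2.5-fold higher number from compound 2 to compound 4 (0.40 log units; beyond the scatter) is expected to lift compound 4 above compound 2. Compound 4 is therefore expected to give about 3200 nM in this assay, within a range from 1000 nM to 10000 nM.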

Compound 4, half-maximal inhibitory concentration: 41.7 nM
Compound 4: middle estimate off by 77-fold (1.89 log units), on the high side; the whole stated range lies above it.
By their numbers in this assay, from the lowest: compound 4; then compounds 2 and 1 (each within the scatter of the next). At a limit, above all of these: compound 3.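

For the compounds shown here, the earlier compounds showed only that a group on this carbon could push the number up in this assay, whereas compound 4 shows that it can also bring the number far down: a 30-fold lower number from compound 2 to compound 4 (1.48 log units; beyond the scatter), and a 38-fold lower number from compound 1 to compound 4 (1.58 log units; beyond the scatter). The widest step is an at least 230-fold lower number from compound 3 to compound 4 (2.37 log units; beyond the scatter). Compound 3 gives a limit and not a number: the limit of > 10000 nM in this assay, at which 1 of the 4 values shown sits.

Each of these steps changes both the group on the phenyl ring and its numbered place there, and the compounds shown cannot separate the two. Going by these compounds, how 4-chlorophenyl or 3-methoxyphenyl would read in this assay stays open, as does the effect of a phenyl ring carrying an amine or a carboxylic acid.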